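This account rests on a few compounds, and the source may have more. Where it says the series, first, only, none or still open, it means among the compounds named here.

Measured so far in an ADME assay on GES1 cells (Homo sapiens) for cytotoxicity, read by MTT assay, with a stated time of 24 h; on this read-out lower numbers stand for higher toxicity in this test and higher numbers for lower toxicity in this test:
- compound 1 `O=c1[nH]cc(S(=O)(=O)Nc2ccccc2-c2cn(-c3ccccc3)nn2)c(=O)[nH]1` gives > 100000 nM, which is a limit of this assay.
- compound 2 `Cc1ccccc1-n1cc(-c2ccccc2NS(=O)(=O)c2c[nH]c(=O)[nH]c2=O)nn1` gives 19900 nM.
- compound 3 `Cc1cccc(-n2cc(-c3ccccc3NS(=O)(=O)c3c[nH]c(=O)[nH]c3=O)nn2)c1` gives 23700 nM.

Among the two numbers, compound 3 has the highest, and its only neighbour is compound 2 with the step of a 1.2-fold higher number from compound 2 to compound 3 (0.08 log units; within the scatter). The value of compound 1 is a limit only (the limit of > 100000 nM in this assay, at which 1 of the 3 values shown sits). The two steps from compound 1, an at least 5.0-fold lower number from compound 1 to compound 2 (0.70 log units; beyond the scatter) and an at least 4.2-fold lower number from compound 1 to compound 3 (0.62 log units; beyond the scatter), both go toward lower numbers once a methylphenyl replaces the phenyl on the ring nitrogen; between the two methylphenyl compounds themselves nothing beyond the scatter appears.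

Compound 4 `Cc1ccc(-n2cc(-c3ccccc3NS(=O)(=O)c3c[nH]c(=O)[nH]c3=O)nn2)cc1` is the next member of this set, differing from compound 3 as follows: 4-methylphenyl in place of 3-methylphenyl on an aromatic nitrogen. Among the compounds with values here, the step that bears on it most directly is the one between compound 2 and compound 3, which is also a swap of one methylphenyl for another on the same nitrogen and stayed within the scatter. The larger steps from compound 1 concern the gain of a methyl, not its placement, so they do not argue for a further change here. A step within the scatter is therefore expected, with the estimate a 1.1-fold lower number from compound 3 to compound 4 (0.03 log units; within the scatter); compound 4 is expected to give 22000 nM, with a range of 9000 nM to 55000 nM.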

Compound 4, half-maximal cytotoxic concentration: 32400 nM
Estimate against measurement, compound 4: 1.5-fold (0.17 log units) below; the measured number falls inside the stated range.
By their numbers in this assay, from the lowest: compounds 2, 3 and 4 (each within the scatter of the next). At a limit, above all of these: compound 1.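

With the 4-methylphenyl on the aromatic nitrogen, three placements of the methyl can be compared in this assay, and the placement shows no effect beyond the scatter: a 1.4-fold higher number from compound 3 to compound 4 (0.14 log units; within the scatter) and a 1.6-fold higher number from compound 2 to compound 4 (0.21 log units; within the scatter). The gain of the methyl keeps the direction seen with compound 2 and compound 3, as shown by an at least 3.0-fold lower number from compound 1 to compound 4 (0.48 log units; beyond the scatter), so all three methylphenyl compounds now lie on the lower side of the phenyl compound. The value of compound 1 is a limit, so the steps from it bound the size of this change without fixing it: the limit of > 100000 nM in this assay, at which 1 of the 4 values shown sits.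

From the compounds shown here alone, because only methyl appears on this phenyl, it remains open whether placement stays without a readable effect for a methoxy group, a chlorine atom, a carboxylic acid or an amine. Going by these compounds, it also remains open whether an ethyl group or a longer chain would take the numbers further from the limit of compound 1 or leave them level with those of the methylphenyl compounds.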